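The source may hold more compounds than are shown below. What is called first, only, known or untested is meant among the compounds shown, and "the series" means these compounds.

The series consists of three close relatives built on one shared core. Compound 1 `CCOC(=O)C[C@H]1[C@@H](O[Si](C)(C)C(C)(C)C)[C@H](n2cnc3c(NC(=O)Nc4ccccc4)ncnc32)O[C@@H]1COC(=O)NC` and compound 2 `CNC(=O)NC[C@H]1O[C@@H](n2cnc3c(NC(=O)Nc4ccccc4)ncnc32)[C@H](O[Si](C)(C)C(C)(C)C)[C@@H]1CC(=O)N(C)OC` have been measured in a functional assay on Hs-578T cells (Homo sapiens) for antiproliferative activity; on this read-out higher numbers stand for weaker inhibition of growth and lower numbers for stronger inhibition of growth: compound 1 gives 3.39 nM, and compound 2 gives 5.79 nM. Within the data shown here, compound 2 thus holds the higher of the two numbers so far, but its only neighbour, compound 1, sits within the usual scatter of it, so the two cannot be ranked against one another.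

Compound 3 `CCOC(=O)C[C@H]1[C@@H](O[Si](C)(C)C(C)(C)C)[C@H](n2cnc3c(NC(=O)Nc4ccccc4)ncnc32)O[C@@H]1CNC(=O)NC` has not yet been measured in this assay. Relative to compound 2 it carries a single change: ethoxy in place of methoxy(methyl)amino on a carbonyl carbon. Among the measured compounds shown here, with no step between measured compounds to draw on, the account can only note that the two numbers in hand lie close together, and no clear direction is expected for the move from compound 2 to compound 3, whose expected size is a 1.3-fold lower number from compound 2 to compound 3 (0.11 log units; within the scatter). Compound 3 is accordingly estimated at 4.5 nM, within a range from 2 nM to 10 nM.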

Compound 3, concentration for 50% growth inhibition: 3.6 nM
Compound 3: middle estimate off by 1.3-fold (0.10 log units), on the high side, within the range that was stated.
By their numbers in this assay, from the lowest: compounds 1, 3 and 2 (each within the scatter of the next).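

On the carbonyl carbon, ethoxy in place of methoxy(methyl)amino gives a 1.6-fold lower number from compound 2 to compound 3 (0.21 log units; within the scatter) in this assay, so these two groups cannot be told apart on this read-out. Among these compounds, on the saturated chain carbon bound to a saturated ring carbon, (methylcarbamoyl)amino in place of (methylcarbamoyl)oxy gives a 1.1-fold higher number from compound 1 to compound 3 (0.03 log units; within the scatter), again with no separation between the pair. Compound 3 thus turns a comparison of two compounds differing in two places into two single-place readings, neither of which goes beyond the scatter.

No measurement shown here offers an explanation for these results. From the compounds shown here alone, it remains open whether a carboxylic acid or a primary amide on the carbonyl carbon, or a simple amine on the saturated chain carbon, would also stay within the scatter in this assay.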